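This account rests on a few compounds, and the source may have more. Where it says the series, first, only, none or still open, it means among the compounds named here.

In a functional assay on DU-145 cells (Homo sapiens) for inhibition, read by trypan blue exclusion, with a stated time of 96 h (a higher number here means a weaker inhibitor of growth, a lower number a stronger inhibitor of growth), compound 2 `O=C(O)c1ccc(C(=O)/C(=C\c2ccc(F)c([N+](=O)[O-])c2)SCc2ccc(C(F)(F)F)cc2)cc1` gives 1000 nM, and compound 3 `O=C(O)c1ccc(C(=O)/C(=C\c2ccc(Cl)c([N+](=O)[O-])c2)SCc2ccc(C(F)(F)F)cc2)cc1` gives 1000 nM, level with it. The step between them is no change at the digits printed from compound 2 to compound 3 (within the scatter), and it concerns a different group from the one changed here. Compound 4 `O=C(O)c1ccc(C(=O)/C(=C\c2ccc(F)c([N+](=O)[O-])c2)SCc2ccc(F)cc2)cc1` departs from compound 2 by fluoro in place of trifluoromethyl on an aromatic carbon, turning 4-(trifluoromethyl)benzyl into 4-fluorobenzyl. Among the measured compounds shown here, no measured step makes this change. Compound 1 `O=C(O)c1ccc(C(=O)/C(=C\c2ccc(Br)cc2)SCc2ccc(F)cc2)cc1` also carries 4-fluorobenzyl, differs elsewhere too, and gives > 100000 nM, which is a limit of the assay and not a number. A modest weakening is therefore expected, with the estimated step being a 3.0-fold higher number from compound 2 to compound 4 (0.48 log units; beyond the scatter). For compound 4 the expected value is 3000 nM, within an estimated range of 700 nM to 30000 nM.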

Compound 4, concentration for 50% growth inhibition: 1000 nM
The estimate for compound 4 lay 3.0-fold (0.48 log units) above the measured number, within the range that was stated.
By their numbers in this assay, from the lowest: compounds 2, 3 and 4 (each within the scatter of the next). At a limit, above all of these: compound 1.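

In this assay, the change from 4-(trifluoromethyl)benzyl to 4-fluorobenzyl gives no change at the digits printed from compound 2 to compound 4 (within the scatter), so the two groups are not told apart at this aromatic carbon. With 4-fluorobenzyl held constant, 4-fluoro-3-nitrophenyl in place of 4-bromophenyl gives an at least 100-fold lower number from compound 1 to compound 4 (2.00 log units; beyond the scatter), a step that starts from a limit of the assay and not from a number: the limit of > 100000 nM in this assay, at which 1 of the 4 values shown sits.

The compounds shown leave open whether an amine or a methoxy group on the same aromatic carbon would hold this level. They also leave open whether the nitro group or the fluoro group of 4-fluoro-3-nitrophenyl carries the step from compound 1.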